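From 4-bromophenyl to 2,4,5-trichlorophenyl on the shared core

This account rests on a few compounds, and the source may have more. Where it says the series, first, only, none or still open, it means among the compounds named here.

Among the measured compounds shown here, in a functional assay on MDA-MB-231 cells (Homo sapiens) for antiproliferative activity, read by MTT assay, with a stated time of 72 h (a lower number here means a stronger inhibitor, a higher number a weaker inhibitor), compound 2 (`NC1=NC2(CCSCC2)N(OCCCOc2ccc(Br)cc2)C(N)=N1`) reads 440 nM and holds the higher of the two numbers so far, which makes it the weaker inhibitor of the measured pair. Compound 1 (`NC1=NC2(CCSCC2)N(OCCCOc2ccc(Cl)c(Cl)c2)C(N)=N1`) gives 10 nM in this assay on the same core.

Compound 3 (`NC1=NC2(CCSCC2)N(OCCCOc2cc(Cl)c(Cl)cc2Cl)C(N)=N1`) has not been measured. It carries 2,4,5-trichlorophenyl in place of 4-bromophenyl, on an oxygen on a saturated carbon (2,4,5-trichlorophenyl in place of 4-bromophenyl on an oxygen on a saturated carbon).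

For the measured compounds named here, only one measured step bears on this change: a 44-fold higher number from compound 1 to compound 2 (1.64 log units; beyond the scatter) with 4-bromophenyl in place of 3,4-dichlorophenyl at that same place, a large step beyond the scatter. The group entering compound 3 is chlorinated, as is the group of compound 1 at 10 nM in this series, so most of that gap is expected to close. Going by the values given here, no measured compound carries 2,4,5-trichlorophenyl, and a single step is thin support.

The expected change is an 18-fold lower number from compound 2 to compound 3 (1.25 log units; beyond the scatter) towards stronger inhibition, a large step beyond the scatter. For compound 3 the estimated value is 25 nM with 5 nM to 120 nM as the expected range.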

Compound 3, half-maximal inhibitory concentration: 110 nM
Beside the measured number, compound 3's estimate is 4.4-fold (0.64 log units) below it, within the range that was stated.
By their numbers in this assay, from the lowest: compound 1; then compound 3; then compound 2.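

In this assay the change to 2,4,5-trichlorophenyl at this place on an oxygen on a saturated carbon gives a 4.0-fold lower number from compound 2 to compound 3 (0.60 log units; beyond the scatter) and so improves on 4-bromophenyl, but by much less than the gap the earlier pair showed. The chlorinated groups do not read alike: chloro in place of hydrogen on an aromatic carbon, taking 3,4-dichlorophenyl to 2,4,5-trichlorophenyl, gives an 11-fold higher number from compound 1 to compound 3 (1.04 log units; beyond the scatter) and shows that one added chloro on this ring can weaken the inhibitor, so a count of chlorines does not set the order among these three compounds. No measurement accompanies these compounds that would account for either step.

The compounds shown leave open whether the loss belongs to the added chloro at that particular ring carbon or to any third substituent on the ring, a question that 2,4-dichlorophenyl or 2,5-dichlorophenyl at this place would bear on. They also leave open how far bromine and chlorine differ here, which 4-chlorophenyl on the shared core would address, and how a longer chain to the same aryl groups would read.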